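A Single Halogen Swap Repeated on a Second Core

This account rests on a few compounds, and the source may have more. Where it says the series, first, only, none or still open, it means among the compounds named here.

Of the compounds shown here, three built on one shared core have been measured in a functional assay on the whole organism (artery, strain albino) with Rattus norvegicus as the target, with a stated time of 900 min, at a dose of 10 mg/kg by the oral route; on this read-out higher numbers stand for more inhibition at the one dose given (going by the name of the read-out) and lower numbers for less inhibition. Compound 1, `CC1=C(C(=O)Nc2ccc(F)cc2)C(c2ccc([N+](=O)[O-])cc2)N=C(SCc2ccc(Cl)cc2)N1`, gives 16.9%. Compound 2, `CC1=C(C(=O)Nc2ccc(F)cc2)C(c2ccc([N+](=O)[O-])cc2)N=C(SCc2ccc(F)cc2)N1`, gives 13.8%. The two differ only in fluoro in place of chloro on an aromatic carbon, and the step of a number 3.1 percentage points lower from compound 1 to compound 2 (within the scatter). Compound 3, `COc1ccc(C2N=C(SCc3ccc(Cl)cc3)NC(C)=C2C(=O)Nc2ccc(Br)cc2)cc1`, gives 20%; its value is within the scatter of both compound 1 and compound 2, so no order among the three can be read from these numbers. The difference between the core of compound 3 and the core of compound 1 is not broken down here.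

Compound 4, `COc1ccc(C2N=C(SCc3ccc(F)cc3)NC(C)=C2C(=O)Nc2ccc(Br)cc2)cc1`, has not yet been measured in this assay. It stands to compound 3 as compound 2 stands to compound 1: the change is fluoro in place of chloro on an aromatic carbon, and the surroundings of the place are described in the same words for both pairs, so this is the same change made a second time on a different core. Among the measured compounds shown here, the only guide is the single earlier step, which rests on compound 1 and compound 2 and lay within the scatter. On that basis the step of a number 3 percentage points lower from compound 3 to compound 4 (within the scatter) is expected, a small movement of roughly the size seen before. Compound 4 is therefore estimated to give 17% in this assay, with an expected range from 8% to 27%, the width reflecting how little one step within scatter can carry.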

Compound 4, a percentage reported as inhibition, in the whole organism at one dose (the size of the read-out at that dose, not a potency): 15.4%
Compound 4: the middle estimate sits 1.6 percentage points above what was measured, and the stated range covers the measured number.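

In this assay the exchange of chloro for fluoro on the second core comes out as a number 4.6 percentage points lower from compound 3 to compound 4 (within the scatter), and set beside the first case the two steps read as follows: the same change on two cores in this assay, a number 3.1 percentage points lower (within the scatter) from compound 1 to compound 2 and a number 4.6 percentage points lower (within the scatter) from compound 3 to compound 4, 1.5 percentage points apart, within the scatter of two such steps

As far as this read-out can tell, then, the 4-chlorobenzyl to 4-fluorobenzyl change gives steps of similar size on the two cores, and nothing in these four compounds marks the second core as responding differently from the first. This does not show that the change itself has any effect on the inhibition, for each step taken alone lies within the scatter, and agreement between two small steps is weak support, resting on one dose and on two cores only, with no claim possible for a core beyond these.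

The compounds shown hold only chloro or fluoro at this place on the benzyl ring, so it stays open how a group of a different kind there, such as a nitrile, a trifluoromethyl, an amine or a carboxylic acid, would read in this assay. Also open, as far as these compounds go, is whether a larger step would appear with any of these, and whether such a step would then carry from one core to the other.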